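This account rests on a few compounds, and the source may have more. Where it says the series, first, only, none or still open, it means among the compounds named here.

Measured so far:
- Compound 1 `COc1cc(C(=O)Nc2ccc(C(=O)/C=C/c3nc(C)c(C)nc3C)cc2)cc(OC)c1OC`: 4740 nM
- Compound 2 `Cc1nc(C)c(/C=C/C(=O)c2ccc(NC(=O)c3ccc(F)cc3)cc2)nc1C`: 1670 nM

Among the compounds with values here, in a functional assay on MDA-MB-231 cells (Homo sapiens) for antiproliferative activity, read by CCK-8 assay, with a stated time of 72 h (on this read-out higher numbers stand for weaker inhibition and lower numbers for stronger inhibition), compound 2 gives 1670 nM, the lower of the two numbers so far. Its gap to compound 1 lies beyond the usual scatter of repeated measurements, but the two compounds differ in more than one place, so the gap cannot be tied to a single change.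

The next compound is compound 3 `COc1ccc(C(=O)Nc2ccc(C(=O)/C=C/c3nc(C)c(C)nc3C)cc2)cc1`. It keeps the rest of compound 2 and has methoxy in place of fluoro on an aromatic carbon, para to a large group: methoxy in place of fluoro on an aromatic carbon.

Within the data shown here, no measured pair differs in one place only, so the data offer no direct guide to the size of this change. Compound 1 also carries methoxy groups and gives 4740 nM, which weakly suggests a shift towards a higher number. The expected step of a 1.5-fold higher number from compound 2 to compound 3 (0.18 log units; within the scatter) is small, towards weaker inhibition, and may stay within the scatter. For compound 3 the estimated value in this assay is 2500 nM, with an expected range from 1000 nM to 6000 nM.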

Compound 3, half-maximal inhibitory concentration: 1600 nM
Compound 3: the middle estimate sits 1.6-fold (0.19 log units) above what was measured; the measured number falls inside the stated range.
By their numbers in this assay, from the lowest: compounds 3 and 2 (each within the scatter of the next); then compound 1.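

In this assay, putting methoxy in place of fluoro on an aromatic carbon, para to a large group, gives a 1.0-fold lower number from compound 2 to compound 3 (0.02 log units; within the scatter). Within the data shown here, this is the first comparison here in which only one place changes, and it shows no difference between the two groups that can be told apart from repeat-to-repeat variation in the measurement. At this position, then, a single fluorine can be exchanged for the 2 heavy atoms of methoxy, which add a hydrogen-bond acceptor, with no detectable effect on the read-out, although no accompanying measurement sheds light on why the two compounds read alike.

This single pair cannot show whether the position would tolerate groups of a different kind, such as an amine, a carboxylic acid or a longer chain like butoxy, or whether some of them would move the number well beyond the scatter. It also leaves open whether fluoro and methoxy would read alike at other places on the same ring, or on a different core.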